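A few compounds are considered here, and "the series" means these few. Any claim that something is new, unique, unknown or untested is made for them only; others in the source may bear on it.

Compound 1 `COCCCCCCCCCCCCCCC/C=C1\CC(CO)(COC(=O)C(C)(C)C)OC1=O`: 0.118 ug/mL
Compound 2 `CC(C)(C)C(=O)OCC1(CO)C/C(=C\CCCCCCCCCCCCCCC=O)C(=O)O1`: > 10 ug/mL (a limit)

In a functional assay on COLO 205 cells (Homo sapiens) for antiproliferative activity (a higher number here means a weaker inhibitor of growth, a lower number a stronger inhibitor of growth), compound 2 stands at > 10 ug/mL, which is a limit of the assay and not a number. Compound 3 `CC(=O)NCCCCCCCCCCCCCCC/C=C1\CC(CO)(COC(=O)C(C)(C)C)OC1=O` differs from it as follows: acetamidomethyl in place of formyl on a saturated chain carbon, ten or more bonds along the chain from a double-bonded chain carbon. This puts acetamidomethyl in place of formyl on a saturated chain carbon, ten or more bonds along the chain from a double-bonded chain carbon. For the measured compounds named here, the one measured step bearing on this change is large: an at least 84-fold higher number from compound 1 to compound 2 (1.92 log units; beyond the scatter). That step brought in the formyl that now leaves, but compound 3 does not regain the methoxymethyl of compound 1, so a partial return is expected. The expected size of the change, toward a lower number, is an at least 10-fold lower number from compound 2 to compound 3 (1.00 log units; beyond the scatter). The estimated value for compound 3 is 1 ug/mL, with a range of 0.15 ug/mL to 8 ug/mL.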

Compound 3, concentration for 50% growth inhibition: 4.74 ug/mL
Estimate against measurement, compound 3: 4.7-fold (0.68 log units) below; the range from low to high includes it.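

In this assay, acetamidomethyl in place of formyl gives an at least 2.1-fold lower number from compound 2 to compound 3 (0.32 log units; beyond the scatter), so some growth inhibition returns. The acetamido group still falls well short of the methoxy group, with a 40-fold higher number from compound 1 to compound 3 (1.60 log units; beyond the scatter), which shows that this place on the chain responds to which group it carries, not merely to whether one is there. On these data alone, the figure for compound 2 is a limit of the assay and not a number, so the full size of the recovery stays unknown: the limit of > 10 ug/mL in this assay, at which 1 of the 3 values shown sits.

As far as these compounds go, whether an amine or a carboxylic acid here would match compound 1 remains open. So does the effect of a longer chain.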